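The source may report more compounds than this note shows. Statements on the series, on what has been measured and on what is new or still open speak of the compounds shown alone.

Of the compounds shown here, three sharing one core have been measured. Compound 1 `O=[N+]([O-])c1ccc(CN2CCC(n3cc(CC(OCc4cc(-c5ccc(Br)cc5)no4)c4ccc(Br)cc4)nn3)CC2)cc1` gives 5000 nM in a functional assay on MDA-MB-468 cells (Homo sapiens) for cytotoxicity, with a stated time of 48 h; on this read-out higher numbers stand for weaker inhibition and lower numbers for stronger inhibition. Compound 2 `N#Cc1cccc(-c2cc(COC(Cc3cn(C4CCN(Cc5ccc([N+](=O)[O-])cc5)CC4)nn3)c3ccc(Br)cc3)on2)c1` returns no number in this assay but only a limit of the assay, > 25000 nM, which is the limit of > 25000 nM in this assay, at which 1 of the 3 values shown sits. Compound 3 `O=[N+]([O-])c1ccc(CN2CCC(n3cc(CC(OCc4cc(-c5ccccc5F)no4)c4ccc(Br)cc4)nn3)CC2)cc1` gives 4000 nM in this assay, and it stands together with compound 1, its nearest neighbour, since a 1.3-fold lower number from compound 1 to compound 3 (0.10 log units; within the scatter). By contrast an at least 5.0-fold higher number from compound 1 to compound 2 (0.69 log units; beyond the scatter) and an at least 6.2-fold lower number from compound 2 to compound 3 (0.79 log units; beyond the scatter) both lie beyond the scatter, so the 3-cyanophenyl is the group at this aromatic carbon that stands out.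

Compound 4 `COc1ccccc1-c1cc(COC(Cc2cn(C3CCN(Cc4ccc([N+](=O)[O-])cc4)CC3)nn2)c2ccc(Br)cc2)on1` has not yet been measured. It differs from compound 3 in one place: methoxy in place of fluoro on an aromatic carbon. For the measured compounds named here, no measured step puts in a methoxy, and none alters a group ortho to a large group. The steps at this position show that such an exchange can leave the number unchanged or raise it. For compound 4 the expected step is a 1.5-fold higher number from compound 3 to compound 4 (0.18 log units; within the scatter), a small move toward a higher number. Compound 4 is therefore estimated at 6000 nM, between 2000 nM and 18000 nM.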

Compound 4, half-maximal inhibitory concentration: > 25000 nM
Compound 4 gave a limit, no number (the forecaster's own chance of this, stated with the estimate: 15%); middle value at least 4.1-fold (0.61 log units) from the limit.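

Compound 4 gives only a limit in this assay and not a number, and it shares that limit with compound 2: the limit of > 25000 nM in this assay, at which 2 of the 4 values shown sit. For the compounds shown here, the fluoro-to-methoxy exchange on this aromatic carbon gives an at least 6.2-fold higher number from compound 3 to compound 4 (0.79 log units; beyond the scatter) and the comparison with the 4-bromophenyl group gives an at least 5.0-fold higher number from compound 1 to compound 4 (0.69 log units; beyond the scatter) so 3-cyanophenyl is no longer the only group here that departs from compound 1 and compound 3. The 2-fluorophenyl and 2-methoxyphenyl groups also part ways, so a group ortho to a large group is not tolerated in every case, and the step between compound 2 and compound 4 cannot be read.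

As far as these compounds go, how far compound 4 lies past the limit stays open. So does whether a hydroxyl, a chloro or an amine at this place would return a number.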